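A few compounds are considered here, and "the series" means these few. Any claim that something is new, unique, unknown or untested is made for them only; others in the source may bear on it.

Compound 1 `Cc1cc(-c2ccc(C#N)cc2)cc(C)c1Oc1nc(Nc2ccc(C#N)c(F)c2)nc2sccc12`, compound 2 `Cc1cc(-c2ccc(C#N)cc2)cc(C)c1Oc1nc(Nc2ccc(C#N)nc2)nc2sccc12` and compound 3 `Cc1cc(-c2ccc(F)cc2)cc(C)c1Oc1nc(Nc2ccc(C#N)c(F)c2)nc2ccsc12` were tested in a toxicity assay on MT4 cells (Homo sapiens) for cytotoxicity, read by MTT assay, with a stated time of 5 days; on this read-out lower numbers stand for higher toxicity in this test and higher numbers for lower toxicity in this test. For compound 1 the assay reports only a limit, > 254000 nM, which is also (the limit of > 254000 nM in this assay, at which 1 of the 3 values shown sits). Compound 2 gives 181000 nM, and compound 3 gives 97300 nM. From compound 1 to compound 2 the change is 6-cyanopyridin-3-yl in place of 4-cyano-3-fluorophenyl on a nitrogen on an aromatic ring, and it brings an at least 1.4-fold lower number from compound 1 to compound 2 (0.14 log units; that floor lies within the scatter). The same change leads from compound 3 to compound 4 `Cc1cc(-c2ccc(F)cc2)cc(C)c1Oc1nc(Nc2ccc(C#N)nc2)nc2ccsc12`, namely (6-cyanopyridin-3-yl in place of 4-cyano-3-fluorophenyl on a nitrogen on an aromatic ring); the place is the same in both pairs, so this is the same change. How the core of compound 3 differs from that of compound 1 is not broken down here. Compound 4 has not yet been measured in this assay. Because the earlier step of an at least 1.4-fold lower number from compound 1 to compound 2 (0.14 log units; that floor lies within the scatter) stays within the scatter, compound 4 is expected to show a 1.2-fold lower number from compound 3 to compound 4 (0.09 log units; within the scatter). Compound 4 is therefore estimated at 80000 nM, most likely between 40000 nM and 180000 nM.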

Compound 4, half-maximal cytotoxic concentration: 6130 nM
Beside the measured number, compound 4's estimate is 13-fold (1.12 log units) above it, and the stated range ends above it.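

In this assay, placing 6-cyanopyridin-3-yl where 4-cyano-3-fluorophenyl stood gives a 16-fold lower number from compound 3 to compound 4 (1.20 log units; beyond the scatter), so on the core of compound 3 this change has a large effect. This does not show whether the change carries the same size from one core to another: the same change on two cores in this assay, an at least 1.4-fold lower number (0.14 log units; that floor lies within the scatter) from compound 1 to compound 2 and a 16-fold lower number (1.20 log units; beyond the scatter) from compound 3 to compound 4; the limit leaves it open whether they differ. Compound 1 contributes only a limit to that comparison: the limit of > 254000 nM in this assay, at which 1 of the 4 values shown sits.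

The compounds shown leave open how the change would read on any further core, and which part of the difference between the two cores matters. Also open, as far as these compounds go, is how an amine or a carboxylic acid in place of the nitrile would read in this assay.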